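The source may report more compounds than this note shows. Statements on the series, on what has been measured and on what is new or still open speak of the compounds shown alone.

Measured so far in an in vitro functional assay on HEK285-7 cells for antagonist activity at prostaglandin D2 receptor 2 (Homo sapiens), read by BRET and beta-arrestin recruitment; a lower number here means a smaller maximal response, a higher number a larger maximal response:

- compound 1, `Nc1nc(-c2ccc(Cl)cc2)c(CC(=O)O)s1`: 50%
- compound 2, `O=C(O)Cc1sc(C(c2ccc(F)cc2)c2ccc(F)cc2)nc1-c1ccnc(F)c1`: 80%

Both compounds carry the same acidic side chain on a shared core and differ elsewhere in several places at once. In this assay compound 1 reaches 50%, while compound 2 reaches 80%. Compound 2 thus stands highest of the two numbers, and the gap between it and compound 1 lies beyond the usual scatter of repeated measurements. Since the two differ in more than one place, nothing can be said about which part of the structure accounts for that gap.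

Compound 3, `COc1cc(-c2nc(C(c3ccc(F)cc3)c3ccc(F)cc3)sc2CC(=O)O)ccn1`, has not yet been measured. It differs from compound 2 in a single place: methoxy in place of fluoro on an aromatic carbon. Within the data shown here, no pair of measured compounds shows what a change of this kind does in this assay, so there is no measured step to lean on. With nothing in the data pointing either way, the step from compound 2 to compound 3 is expected to be small, a number 2 percentage points lower from compound 2 to compound 3 (within the scatter), and to stay within the scatter in either direction. Compound 3 is therefore estimated at 78%, with a range from 60% to 95%.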

Compound 3, largest response reached (reported as efficacy), in percent of the reference or control that the assay uses: 60%
Beside the measured number, compound 3's estimate is 18 percentage points above it, and the stated range covers the measured number.
By their numbers in this assay, from the lowest: compounds 1 and 3 (each within the scatter of the next); then compound 2.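

In this assay, among these compounds, putting methoxy in place of fluoro on an aromatic carbon next to the ring nitrogen gives a number 20 percentage points lower from compound 2 to compound 3 (beyond the scatter), and this is the only measured step here between compounds that differ in one place. It shows that this position is not indifferent to what sits on it. With the rest of the structure unchanged, going from 2-fluoropyridin-4-yl to 2-methoxypyridin-4-yl lowers the maximal response by more than the usual scatter of repeated measurements. Nothing measured alongside these numbers says why this single change has that effect.

With only fluoro and methoxy seen at this carbon, the compounds shown give two points and no trend, so it stays open where a chloro, an ethoxy or an amine would fall relative to compound 2 and compound 3. Among the compounds shown here, it also stays open whether the same swap would lower the response by a similar amount on a different structure, since it has been seen only with the rest of compound 2 around it.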